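This account rests on a few compounds, and the source may have more. Where it says the series, first, only, none or still open, it means among the compounds named here.

Measured so far in a toxicity assay on CHO cells (Cricetulus griseus) for cytotoxicity, read by WST assay, with a stated time of 24 h; on this read-out lower numbers stand for stronger inhibition and higher numbers for weaker inhibition:

- compound 1 `CC(C)=CCCC(C)=CCNCCCN1CCCC1` gives > 150000 nM (a limit)
- compound 2 `CC(C)=CCC/C(C)=C\CCC(C)=CCNCCN` gives 32300 nM
- compound 3 `CC(C)=CCC/C(C)=C\CCC(C)=CCNCCCCN` gives 18100 nM

Compound 1 sits at a limit of the assay, > 150000 nM, so it offers a boundary and not a number. Among the measured compounds shown here, that leaves compound 2 and compound 3 as the only two compounds with true numbers, and those two lie within the scatter of each other. For the measured compounds named here, compound 3 therefore stands level with its one numerical neighbour.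

The next compound is compound 4 `CC(C)=CCC/C(C)=C\CCC(C)=CCNCCCN1CCCC1`. It is made from compound 3 by one change at the end of the chain: pyrrolidin-1-yl in place of aminomethyl on a saturated chain carbon, three bonds along the chain from an amine nitrogen. In plain terms, pyrrolidin-1-yl takes the place of aminomethyl, on a saturated chain carbon, three bonds along the chain from an amine nitrogen.

Going by the values given here, only one measured step bears on this, a 1.8-fold lower number from compound 2 to compound 3 (0.25 log units; within the scatter). It also alters the amine-bearing chain end, and it stayed small. Among the compounds with values here, no measured step covers the ring itself, so the evidence is thin. On that basis no shift beyond the scatter is expected in this assay, and the expected step is a 1.1-fold higher number from compound 3 to compound 4 (0.04 log units; within the scatter).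

For compound 4 the estimated value is 20000 nM, with an expected range of 7000 nM to 60000 nM.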

Compound 4, half-maximal inhibitory concentration: 85300 nM
Compound 4: middle estimate off by 4.3-fold (0.63 log units), on the low side, and the stated range ends below it.
By their numbers in this assay, from the lowest: compounds 3 and 2 (each within the scatter of the next); then compound 4. At a limit, above all of these: compound 1.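

In this assay, the end of the chain proves able to move the number: putting pyrrolidin-1-yl in place of aminomethyl gives a 4.7-fold higher number from compound 3 to compound 4 (0.67 log units; beyond the scatter), and the related change from the shorter amine gives a 2.6-fold higher number from compound 2 to compound 4 (0.42 log units; beyond the scatter), both beyond the scatter and both towards weaker inhibition. The earlier step between the two open-chain amines, a 1.8-fold lower number from compound 2 to compound 3 (0.25 log units; within the scatter), stayed within the scatter, so among these compounds it is the ring-bearing end, and not the difference between 2-aminoethyl and the amino group it replaces, that shows a real shift. Adding 3-methylbut-2-en-1-yl to the tail gives an at least 1.7-fold lower number from compound 1 to compound 4 (0.24 log units; that floor lies within the scatter), but this step starts from a limit and its floor lies within the scatter, so it fixes no size for that change: the limit of > 150000 nM in this assay, at which 1 of the 4 values shown sits.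

These compounds cannot show whether the shift belongs to the ring itself or to the change from an open amine to one that carries no hydrogen-bond donor. A dimethylamino end on the same chain would separate those two readings, and a piperidin-1-yl end would test whether the size of the ring matters.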